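Series notes: from compound 2 to compound 4

The compounds below may be only part of what the source reports. "The series", "measured", "known", "first", "only" and "open" are said of these compounds alone.

Values in a physicochemical assay for lipophilicity; a lower number here means a more polar compound, a higher number a more lipophilic compound
- compound 1 `Cc1nc(-c2cc(C(F)(F)F)ccc2[C@H]2CCOc3cc(S(=O)(=O)Nc4ccncn4)ccc32)co1` reads "not determined" (no result reported)
- compound 2 `O=S(=O)(Nc1ncccn1)c1ccc2c(c1)OCC[C@@H]2c1ccc(C(F)(F)F)cc1-c1ccc(F)nc1` reads 2.8
- compound 3 `O=S(=O)(Nc1nccs1)c1ccc2c(c1)OCC[C@H]2c1ccc(C(F)(F)F)cc1-n1ccnn1` reads 2.3

Compound 2 (2.8) holds the higher of the two numbers, and compound 3 (2.3) lies lower, beyond the scatter. Compound 4 `Cn1nccc1-c1cc(C(F)(F)F)ccc1[C@H]1CCOc2cc(S(=O)(=O)Nc3ncccn3)ccc21` differs from compound 2 as follows (1-methyl-1H-pyrazol-5-yl in place of 6-fluoropyridin-3-yl on an aromatic carbon): 1-methyl-1H-pyrazol-5-yl in place of 6-fluoropyridin-3-yl on an aromatic carbon. Among the measured compounds shown here, no measured pair isolates this change. Compound 3 (2.3) also carries a five-membered aromatic ring in that place, though it differs elsewhere too, so a small downward step in this assay is expected. The estimated step is (a number 0.30 log units lower from compound 2 to compound 4 (within the scatter)). Compound 4 is estimated at (2.5), with an expected range of (2.1 to 2.9).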

Compound 4, distribution coefficient: 3.7
Compound 4: middle estimate off by 1.20 log units, on the low side; measured number outside the range, above it.
By their numbers in this assay, from the lowest: compound 3; then compound 2; then compound 4.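

In this assay, among the compounds shown here, 1-methyl-1H-pyrazol-5-yl in place of 6-fluoropyridin-3-yl gives a number 0.90 log units higher from compound 2 to compound 4 (beyond the scatter) as the first step here that isolates a single place. The ring on this aromatic carbon, ortho to a large group and meta to a trifluoromethyl group, can therefore shift the reading by itself, and a five-membered aromatic ring there need not lower it. No measurement at hand accounts for the step.

This single pair does not separate ring size from the methyl group or the fluorine. As far as these compounds go, how a ring carrying an amine or a carboxylic acid would read at this position remains open.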